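The source may report more compounds than this note shows. Statements on the series, on what has been measured and on what is new or still open speak of the compounds shown alone.

Compound 1 `O=C(Nc1cc(-c2ccccc2)c(=O)[nH]n1)c1ccccc1`: in an assay for inhibition of casein kinase I isoform alpha (Sus scrofa), read by scintillation counting and 33P incorporation, with a stated time of 30 min, in the presence of a further agent that is not named here (on this read-out lower numbers stand for stronger inhibition and higher numbers for weaker inhibition), compound 1 gives > 10000 nM, which is a limit of the assay and not a number.
Compound 2 `CC(=O)N(C(C)=O)c1n[nH]c(=O)c2ccccc12`: in this assay compound 2 gives > 10000 nM, again a limit.
Compound 3 `CC(=O)Nc1n[nH]c(=O)c2ccccc12`: in this assay compound 3 gives > 10000 nM, again a limit.

Compound 3 therefore stands nowhere on a scale of numbers: its value is a limit, and the two further values shown are limits as well, all three sitting at the limit of > 10000 nM in this assay, at which 3 of the 3 values shown sit. Among the compounds with values here, the only step between measured compounds, a step that the two limits leave unreadable from compound 2 to compound 3, is left unreadable by the two limits, so it gives no measure of how far a change on the amide-type nitrogen moves the read-out.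

Compound 4 `O=C(Nc1n[nH]c(=O)c2ccccc12)c1ccccc1` differs from compound 3 by phenyl in place of methyl on a carbonyl carbon. Within the data shown here, compound 1 carries the same benzamide on a different core and shows only a limit, so no pair with a readable step bears on this change. With nothing readable to build on, no step beyond the scatter is expected in this assay in either direction, and the step from compound 3 to compound 4 is estimated as a step that the limit leaves unreadable from compound 3 to compound 4. Compound 4 is therefore expected to give about 15000 nM, in the range 5000 nM to 50000 nM.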

Compound 4, half-maximal inhibitory concentration: > 10000 nM
Compound 4: no number, only a limit; the forecaster's own chance of this, stated with the estimate: 80%; the middle value is on the limit's open side.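

In this assay compound 4 gives > 10000 nM, which is a limit and not a number. Within the data shown here, no step can therefore be read between compound 3 and compound 4. The compounds shown leave open whether any change among them moves the read-out at all.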